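Methyl-for-hydrogen steps across two cores

The source may hold more compounds than are shown below. What is called first, only, known or untested is meant among the compounds shown, and "the series" means these compounds.

Compound 1 `CCCc1cccc2c(C3=C(Br)C(=O)NC3=O)c(-c3ccc(OC)cc3)[nH]c12` and compound 2 `CCCCc1cccc2c(C3=C(Br)C(=O)NC3=O)c(-c3ccc(OC)cc3)[nH]c12` share one core; compound 3 `COc1cccc(-c2[nH]c3ccc(OC)cc3c2C2=C(Br)C(=O)NC2=O)c1` and compound 4 `CCOc1ccc2[nH]c(-c3cccc(OC)c3)c(C3=C(Br)C(=O)NC3=O)c2c1` share another, and the difference between the two cores is not broken down here. In a physicochemical assay for lipophilicity (a higher number here means a more lipophilic compound, a lower number a more polar compound), compound 1 gives 3.58, compound 2 gives 3.81 and compound 3 gives 2.79. The change from compound 1 to compound 2, (methyl in place of hydrogen on a saturated chain carbon, three bonds along the chain from an aromatic carbon), made a number 0.23 log units higher from compound 1 to compound 2 (within the scatter). The change from compound 3 to compound 4 is methyl in place of hydrogen on a saturated chain carbon bound to an oxygen on an aromatic ring; it is the same kind of change, but its place is a saturated chain carbon bound to an oxygen on an aromatic ring rather than a saturated chain carbon three bonds along the chain from an aromatic carbon. On that basis the expected step in this assay is a number 0.41 log units higher from compound 3 to compound 4 (beyond the scatter), close to a number 0.23 log units higher from compound 1 to compound 2 (within the scatter). Compound 4 is accordingly estimated at 3.2, between 2.9 and 3.6.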

Compound 4, partition coefficient: 2.97
Compound 4: middle estimate off by 0.23 log units, on the high side; low and high end bracket the measured number.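

In this assay, the methoxy to ethoxy change gives a number 0.18 log units higher from compound 3 to compound 4 (within the scatter), and the methyl-for-hydrogen change on the core of compound 1 gives a number 0.23 log units higher from compound 1 to compound 2 (within the scatter). The two cores therefore agree only in that neither step stands clear of the scatter; this does not show that the change has a fixed size from core to core, since the two pairs carry it at different places and rest on one step each. Nothing available bears on the reason for either step.

From the compounds shown here alone, whether a longer chain, such as propoxy, would give a step beyond the scatter remains open. So does the effect of an amine or a carboxylic acid at the end of that chain.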